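Working notes: carboxy in place of hydroxy, compound 4

The compounds below may be only part of what the source reports. "The series", "measured", "known", "first", "only" and "open" are said of these compounds alone.

Measured so far in a functional assay, read by spectrophotometry, with a stated time of 5 min; a lower number here means a stronger inhibitor, a higher number a weaker inhibitor:
compound 1 `Cc1ccc2[nH]c(=O)c(/C=N/c3ccc(O)cc3)cc2c1` gives 235000 nM
compound 2 `O=c1[nH]c2ccccc2cc1/C=N/O` gives 463000 nM
compound 3 `O=c1[nH]c2ccccc2cc1/C=N/c1ccc(O)cc1` gives 306000 nM

Compound 3 sits among three numbers that all lie within the scatter of one another; its nearest neighbour is compound 1 and its furthest compound 2. Among the compounds with values here, the only measured one-place step, a 1.3-fold higher number from compound 1 to compound 3 (0.11 log units; within the scatter), concerns hydrogen in place of methyl on an aromatic carbon and stays within the scatter. Compound 4 `O=C(O)c1ccc(/N=C/c2cc3ccccc3[nH]c2=O)cc1` differs from compound 3 by carboxy in place of hydroxy on an aromatic carbon. Within the data shown here, no measured step touches this position, so nothing measured bears on the change. In this assay a step of about a 1.0-fold lower number from compound 3 to compound 4 (0.01 log units; within the scatter) is expected for compound 4, none beyond the scatter. Compound 4 is estimated at 300000 nM, expected range 120000 nM to 800000 nM.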

Compound 4, half-maximal inhibitory concentration: 381000 nM
Compound 4: middle estimate off by 1.3-fold (0.10 log units), on the low side, and the stated range covers the measured number.
By their numbers in this assay, from the lowest: compounds 1, 3, 4 and 2 (each within the scatter of the next).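

In this assay, the position on the aromatic carbon para to a large group now has a measured step: carboxy in place of hydroxy gives a 1.2-fold higher number from compound 3 to compound 4 (0.10 log units; within the scatter) and so stays within the scatter. With this pair, the assay does not separate the two groups at this position, although carboxy brings more heavy atoms. No measurement on hand explains this outcome.

Still open, on these data alone, is whether an amine, a methoxy group or a nitrile at this position would give a step beyond the scatter. Also open, as far as these compounds go, is whether carboxy would behave the same way on the core of compound 1.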